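Fluoro to trifluoromethyl on the pendant aryl: cytotoxicity

The source may report more compounds than this note shows. Statements on the series, on what has been measured and on what is new or still open speak of the compounds shown alone.

Compound 1 `CC(=O)Nc1ccc2oc(-c3ccc(F)cc3)cc(=O)c2c1` is the starting point; in an ADME assay on THP-1 cells (Homo sapiens) for cytotoxicity, read by flow cytometry and propidium iodide staining, with a stated time of 72 h (on this read-out higher numbers stand for weaker inhibition and lower numbers for stronger inhibition), compound 1 gives 22000 nM. Compound 2 `CC(=O)Nc1ccc2oc(-c3ccc(C(F)(F)F)cc3)cc(=O)c2c1` carries the change trifluoromethyl in place of fluoro on an aromatic carbon and in this assay compound 2 gives 10000 nM, so that change made a 2.2-fold lower number from compound 1 to compound 2 (0.34 log units; beyond the scatter).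

Compound 3 `Nc1ccc2oc(-c3cccc(F)c3)cc(=O)c2c1` rests on a different core; how the two cores differ is not broken down here. For compound 3 this assay reports only a limit, > 125000 nM, not a number.

Compound 4 `Nc1ccc2oc(-c3cccc(C(F)(F)F)c3)cc(=O)c2c1`, not yet measured, carries the change (trifluoromethyl in place of fluoro on an aromatic carbon). The group enters here meta to a large group, whereas from compound 1 to compound 2 it entered para to a large group, so this is the same kind of change rather than the same one. Beside the measured 2.2-fold lower number from compound 1 to compound 2 (0.34 log units; beyond the scatter), the expected step is an at least 1.2-fold lower number from compound 3 to compound 4 (0.09 log units; that floor lies within the scatter), kept small because compound 3 sits at the limit of > 125000 nM in this assay, at which 1 of the 3 values shown sits, and the earlier step was itself modest. Compound 4 is therefore estimated at 100000 nM in this assay, expected between 40000 nM and 250000 nM, with a fair chance that only a limit is reported again.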

Compound 4, half-maximal inhibitory concentration: 34000 nM
Estimate against measurement, compound 4: 2.9-fold (0.47 log units) above, and the stated range ends above it.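

Trifluoromethyl in place of fluoro again lowers the number in this assay, here with an at least 3.6-fold lower number from compound 3 to compound 4 (0.56 log units; beyond the scatter), so the direction of the change holds on both cores shown. How far the size of the step carries from one core to the other stays unresolved: the same change on two cores in this assay, a 2.2-fold lower number (0.34 log units; beyond the scatter) from compound 1 to compound 2 and an at least 3.6-fold lower number (0.56 log units; beyond the scatter) from compound 3 to compound 4; the limit leaves it open whether they differ. With only two pairs to go on, and with compound 3 held as a limit rather than a number, no general rule for this change follows: the limit of > 125000 nM in this assay, at which 1 of the 4 values shown sits.

Still open, as far as these compounds go, is whether a chloro or methoxy group on the pendant aryl would move the number in the same direction as trifluoromethyl. Also open, from the compounds shown here alone, is whether the step depends on the core or on where the group sits, as each core appears here with the change at one place only.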